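Cyclohexyl for phenethyl on the shared core

This account rests on a few compounds, and the source may have more. Where it says the series, first, only, none or still open, it means among the compounds named here.

Going by the values given here, compound 1 `c1ccc(CCc2ccc3c(NCCCNCc4ccco4)ccnc3c2)cc1` carries a furan-2-yl group on the saturated chain carbon bound to an amine nitrogen; in an ADME assay on HepG2 cells (Homo sapiens) for cytotoxicity, read by luminescence, CellTiter-Glo and ATP content, with a stated time of 72 h (a higher number here means that more compound is needed for the effect, a lower number that less compound is needed), compound 1 gives 16000 nM, the highest of the three numbers measured so far. Compound 2 `COc1ccc(F)cc1CNCCCNc1ccnc2cc(CCc3ccccc3)ccc12` gives 4240 nM, and compound 3 `COc1cccc(CNCCCNc2ccnc3cc(CCc4ccccc4)ccc23)c1O` gives 6800 nM. Every measured step concerns the group on that chain carbon: a 3.8-fold lower number from compound 1 to compound 2 (0.58 log units; beyond the scatter), a 2.4-fold lower number from compound 1 to compound 3 (0.37 log units; beyond the scatter), and a 1.6-fold higher number from compound 2 to compound 3 (0.21 log units; within the scatter).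

Compound 4 `c1coc(CNCCCNc2ccnc3cc(C4CCCCC4)ccc23)c1` differs from compound 1 on an aromatic carbon of the core instead: cyclohexyl in place of phenethyl on an aromatic carbon. Among the compounds with values here, no measured step touches that aromatic carbon, so none bears directly on this change; the measured steps show only that varying the chain group moved the number over a modest span. Within the data shown here, with no direct precedent, the expectation for compound 4 in this assay is a step within the scatter in either direction, a 1.1-fold lower number from compound 1 to compound 4 (0.06 log units; within the scatter). Compound 4 is therefore estimated at 14000 nM, in a range from 5000 nM to 40000 nM.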

Compound 4, half-maximal effective concentration: 4760 nM
The estimate for compound 4 lay 2.9-fold (0.47 log units) above the measured number; the whole stated range lies above it.
By their numbers in this assay, from the lowest: compounds 2, 4 and 3 (each within the scatter of the next); then compound 1.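

In this assay there is a 3.4-fold lower number from compound 1 to compound 4 (0.53 log units; beyond the scatter) with cyclohexyl in place of phenethyl, so the number responds to the group on this aromatic carbon of the core and not only to the group on the chain carbon. The change replaces a six-membered aromatic ring with a non-aromatic one and takes the group from 8 heavy atoms to 6, while the furan-2-yl group stays in place. No measurement on hand accounts for this step.

Ring type and group size change together here, so a cyclohexylethyl or phenyl group on the same carbon would be needed to separate them. On these data alone, whether the step carries over to the chain groups of compound 2 and compound 3 also remains open.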